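The source may hold more compounds than are shown below. What is called first, only, known or untested is meant among the compounds shown, and "the series" means these compounds.

Measured so far:
compound 1 `CC(C)CC/N=C(\NC#N)Nc1cc(C(F)(F)F)cc(C(F)(F)F)c1` — in a functional assay (aorta) with Rattus norvegicus as the target (a lower number here means a stronger inhibitor, a higher number a weaker inhibitor), compound 1 gives 5600 nM.
compound 2 `CC(C)/N=C(\NC#N)Nc1cc(C(F)(F)F)cc(C(F)(F)F)c1` — in this assay compound 2 gives 61000 nM.
compound 3 `N#CN/C(=N\C1CCCC1)Nc1cc(C(F)(F)F)cc(C(F)(F)F)c1` — in this assay compound 3 gives only > 300000 nM, which is a limit of the assay and not a number.

Compound 3 stands at the weak end of what has been measured: the step of an at least 53-fold higher number from compound 1 to compound 3 (1.72 log units; beyond the scatter) and the step of an at least 4.9-fold higher number from compound 2 to compound 3 (0.69 log units; beyond the scatter) both run toward it. Its value is a limit (the limit of > 300000 nM in this assay, at which 1 of the 3 values shown sits).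

Compound 4 `COc1cc(N/C(=N/C2CCCC2)NC#N)cc(C(F)(F)F)c1` differs from compound 3 in one place: methoxy in place of trifluoromethyl on an aromatic carbon. Among the compounds with values here, none of the measured steps touches this part of the structure; each of them, an 11-fold higher number from compound 1 to compound 2 (1.04 log units; beyond the scatter) included, changes only the group on the double-bonded nitrogen, and the aromatic substituents are the same in compounds 1, 2 and 3. So no measured step bears on the change from compound 3 to compound 4, and there is no ground to expect movement beyond the scatter in this assay in either direction. Compound 4 is therefore expected to remain at the limit, with an estimate of 300000 nM and a range of 100000 nM to 1000000 nM. The expected step of a number no higher from compound 3 to compound 4 (the limit leaves the size open) is thus about none.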

Compound 4, half-maximal inhibitory concentration: 75000 nM
Compound 4: middle estimate off by 4.0-fold (0.60 log units), on the high side; the measured number lies below the stated range.
By their numbers in this assay, from the lowest: compound 1; then compounds 2 and 4 (each within the scatter of the next). At a limit, above all of these: compound 3.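

The aromatic substituent, constant across compounds 1, 2 and 3, now proves able to move the read-out in this assay: methoxy in place of trifluoromethyl gives an at least 4.0-fold lower number from compound 3 to compound 4 (0.60 log units; beyond the scatter). The group on the double-bonded nitrogen is therefore not the only place on the shared core that counts, and a cyclopentyl compound can give a measurable number once one trifluoromethyl has left. Compound 3 remains at a limit and not a number, so the size of this step has only a bound: the limit of > 300000 nM in this assay, at which 1 of the 4 values shown sits.

A single replacement cannot separate a gain from methoxy itself from a gain from losing trifluoromethyl, and a plain hydrogen, a chlorine or an amine on this carbon would help to tell the two apart. Also open, on these data alone, is whether the same replacement would shift compound 1, with its isopentyl group and 5600 nM, by a similar amount.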